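Swapping methoxy for chloro on a fused heterocyclic core

The source may hold more compounds than are shown below. What is called first, only, known or untested is meant among the compounds shown, and "the series" means these compounds.

Measured compounds:
Compound 1 `COc1cc(C)nc2n/c(=N/C(=O)c3c(-c4ccc(Cl)cc4Cl)noc3C)sn12`: 80.5%
Compound 2 `Cc1onc(-c2ccc(Cl)cc2Cl)c1C(=O)/N=c1/nc2nc(Cl)cc(C)n2s1`: 55.6%
Compound 3 `COc1cc(OC)n2s/c(=N\C(=O)c3c(-c4ccc(Cl)cc4Cl)noc3C)nc2n1`: 85.6%

In a functional assay on the whole organism (strain L.) for inhibition, with Echinochloa crus-galli as the target, with a stated time of 72 h, tested at 100 mg/L (on this read-out higher numbers stand for more inhibition of growth at the one concentration tested and lower numbers for less inhibition of growth), compound 3 gives the highest of the three numbers. Compound 1 sits nearest; the step of a number 5.1 percentage points higher from compound 1 to compound 3 (within the scatter) lies within the scatter, so the two cannot be ordered. Compound 2 lies furthest, well beyond the scatter.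

Compound 4 `COc1cc(Cl)nc2n/c(=N/C(=O)c3c(-c4ccc(Cl)cc4Cl)noc3C)sn12` has not yet been tested. It differs from compound 3 in one place: chloro in place of methoxy on an aromatic carbon. Within the data shown here, no single measured step covers this exact change. Compound 2 also carries a chloro group on its core, yet it differs from compound 1 in two places at once, so its value can only hint. Since the methyl-to-methoxy step a number 5.1 percentage points higher from compound 1 to compound 3 (within the scatter) barely moved the number, the gap between compound 1 and compound 2 is plausibly tied to the chloro group. Compound 4 is therefore expected to fall, with the step of a number 25.6 percentage points lower from compound 3 to compound 4 (beyond the scatter), to an estimated 60%, in the range 45% to 76%.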

Compound 4, percent growth inhibition at one concentration: 40.8%
The estimate for compound 4 lay 19.2 percentage points above the measured number; the whole stated range lies above it.
By their numbers in this assay, from the lowest: compound 4; then compound 2; then compounds 1 and 3 (each within the scatter of the next).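

In this assay, chloro on this aromatic carbon clearly costs inhibition of growth compared with methoxy, with a number 44.8 percentage points lower from compound 3 to compound 4 (beyond the scatter). Chloro in place of methyl points the same way, with a number 39.7 percentage points lower from compound 1 to compound 4 (beyond the scatter), so on this core the loss appears whichever of the two groups chloro replaces. Methoxy in place of methyl, which made no clear difference on a core also carrying methoxy, gives a number 14.8 percentage points lower from compound 2 to compound 4 (beyond the scatter) on a core also carrying chloro, so the outcome of this change depends on what else the core holds: the same change on two cores in this assay, a number 5.1 percentage points higher (within the scatter) from compound 1 to compound 3 and a number 14.8 percentage points lower (beyond the scatter) from compound 2 to compound 4, 19.9 percentage points apart, beyond the scatter of two such steps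

The compounds shown leave open how an amine or a longer chain such as ethoxy would fare on this carbon. They also leave open whether this order would hold at other concentrations, as each compound has a single reading here.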